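A few compounds are considered here, and "the series" means these few. Any claim that something is new, unique, unknown or untested is made for them only; others in the source may bear on it.

In a functional assay on HT-29 cells (Homo sapiens), with a stated time of 24 h (on this read-out higher numbers stand for an effect only at larger amounts of compound and lower numbers for an effect already at smaller amounts), compound 1 (`CC(=O)Oc1ccccc1C(=O)Oc1ccc(CO[N+](=O)[O-])cc1`) gives 107000 nM and compound 2 (`CC(=O)Oc1ccccc1C(=O)Oc1cccc(CO[N+](=O)[O-])c1`) gives 1000000 nM as the higher of the two numbers, a gap beyond the scatter. Compound 3 (`CC(=O)Oc1ccccc1C(=O)Oc1cccc(CO)c1`) differs from compound 2 by hydrogen in place of nitro on an oxygen on a saturated carbon with hydrogen in place of nitro on an oxygen on a saturated carbon, that is, nitrooxy to hydroxy. Among the measured compounds shown here, no measured pair shows this change, and no step beyond the scatter is expected in this assay in either direction. The expected step of a 1.1-fold lower number from compound 2 to compound 3 (0.05 log units; within the scatter) is therefore small. For compound 3 the estimated value is 900000 nM within an expected range from 300000 nM to 2500000 nM on this read-out.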

Compound 3, half-maximal effective concentration: > 1000000 nM
Compound 3: no number, only a limit (the forecaster's own chance of this, stated with the estimate: 30%); middle value at least 1.1-fold (0.04 log units) from the limit.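

Compound 3 gives only a limit in this assay, > 1000000 nM. Replacing nitrooxy with hydroxy on this saturated carbon gives a number no lower from compound 2 to compound 3 (the limit leaves the size open), so removing the nitro does not bring the number down, something compound 1 and compound 2, which both carry nitrooxy, could not show. The reading ends at the assay's limit: the limit of > 1000000 nM in this assay, at which 1 of the 3 values shown sits.

The compounds shown leave open how far compound 3 actually lies from compound 2, and whether the same change would act alike on compound 1. They also leave open what an amine or a carboxylic acid would do in place of the hydroxy.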